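The source may report more compounds than this note shows. Statements on the series, on what has been measured and on what is new or still open speak of the compounds shown alone.

Measured compounds:
compound 1 `COc1ccc(N2C(=O)COc3ccc(-c4cnc5ccccc5c4)cc32)cc1` — > 40000 nM, a limit of the assay, not a number
compound 2 `COc1cccc(N2C(=O)COc3ccc(-c4cnc(Cl)c(NS(=O)(=O)c5ccc(F)cc5)c4)cc32)c1` — > 40000 nM, a limit of the assay, not a number
compound 3 `O=C1COc2ccc(-c3cnc(Cl)c(NS(=O)(=O)c4ccc(F)cc4)c3)cc2N1c1ccccc1` — 36900 nM

Among the compounds with values here, in a functional assay on A-375 cells (Homo sapiens) for antiproliferative activity, read by MTT assay, with a stated time of 72 h (on this read-out lower numbers stand for stronger inhibition and higher numbers for weaker inhibition), compound 3 gives 36900 nM, the only number in the set. The two other values are limits of the assay, as the limit of > 40000 nM in this assay, at which 2 of the 3 values shown sit, records. Within the data shown here, the single step between measured compounds, an at least 1.0-fold lower number from compound 2 to compound 3 (0.03 log units; that floor lies within the scatter), is hydrogen in place of methoxy on an aromatic carbon and lies within the scatter, so nothing in the measured data moves potency beyond the scatter.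

Compound 4 `O=C1COc2ccc(-c3cnc(Cl)c(NS(=O)(=O)c4ccc(F)cc4)c3)cc2N1C1CCCCC1` differs from compound 3 by cyclohexyl in place of phenyl on an amide-type nitrogen in a ring. Among the measured compounds shown here, no measured step swaps an aromatic ring for a non-aromatic one on the amide-type nitrogen in a ring, so none bears directly on this change; the only step on record, an at least 1.0-fold lower number from compound 2 to compound 3 (0.03 log units; that floor lies within the scatter), concerns a substituent elsewhere and stays within the scatter. No step beyond the scatter is therefore expected in this assay, in either direction.

Compound 4 is expected to give 37000 nM, within a range of 12000 nM to 120000 nM, an estimated step of a 1.0-fold higher number from compound 3 to compound 4 (0.00 log units; within the scatter). Because the limit of > 40000 nM in this assay, at which 2 of the 3 values shown sit, lies close to the value of compound 3, a sizeable chance remains that the assay returns only a limit for compound 4.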

Compound 4, half-maximal inhibitory concentration: > 40000 nM
Compound 4: a limit, no number (the forecaster's own chance of this, stated with the estimate: 50%); middle value at least 1.0-fold (0.03 log units) from the limit.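

In this assay compound 4 gives > 40000 nM, a limit of the assay and not a number. Cyclohexyl in place of phenyl on the amide-type nitrogen in a ring gives an at least 1.0-fold higher number from compound 3 to compound 4 (0.03 log units; that floor lies within the scatter), so the first change at this position shows no gain from a non-aromatic ring of the same heavy-atom count, and the true size of the step remains unknown. The step with cyclohexyl in place of 3-methoxyphenyl cannot be read, and phenyl remains the only group at this position with a measured number, so the read-out of this series is still bounded at one end:  the limit of > 40000 nM in this assay, at which 3 of the 4 values shown sit.

Still open, as far as these compounds go, is whether any group on this nitrogen can bring the series clearly under that limit, for example a smaller methyl, a chain ending in a dimethylamino group, or a phenyl carrying a carboxylic acid. The compounds shown also leave open how far phenyl and cyclohexyl truly differ, since the value for compound 4 is only a limit and no number can be set against that of compound 3.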